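Swapping bromine for a chlorophenyl ring

The compounds below may be only part of what the source reports. "The series", "measured", "known", "first", "only" and "open" are said of these compounds alone.

Compound 1 `Brc1cn2ccnc2c(-c2ccc3ncn(C4CCCCC4)c3c2)n1` is the lower of the two compounds measured in a functional assay on HCT-15 cells (Homo sapiens) for inhibition, read by sulforhodamine B assay, with a stated time of 48 h, tested at 10 uM; on this read-out higher numbers stand for more inhibition at the one concentration tested (going by the name of the read-out) and lower numbers for less inhibition: compound 1 gives 13.1%. Among the measured compounds shown here, compound 2 `COc1ccc(-c2cn3ccnc3c(-c3ccc4ncn(C5CCCCC5)c4c3)n2)cc1` gives 78.8%, and the step of a number 65.7 percentage points higher from compound 1 to compound 2 (beyond the scatter) is the only change tested at this position. Compound 3 `Clc1ccc(-c2cn3ccnc3c(-c3ccc4ncn(C5CCCCC5)c4c3)n2)cc1` differs from compound 1 by 4-chlorophenyl in place of bromo on an aromatic carbon. The measured step bears on this change because a number 65.7 percentage points higher from compound 1 to compound 2 (beyond the scatter) also put an aromatic ring in place of the bromine at the same carbon, so a rise is expected in this assay, though the chloro ring is not the methoxy ring. Compound 3 is expected to give 65% (range 35% to 90%), a step of a number 51.9 percentage points higher from compound 1 to compound 3 (beyond the scatter).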

Compound 3, a percentage reported as inhibition, at one concentration (the size of the read-out at that concentration, not a potency): 15.5%
The estimate for compound 3 lay 49.5 percentage points above the measured number; the measured number lies below the stated range.
By their numbers in this assay, from the lowest: compounds 1 and 3 (each within the scatter of the next); then compound 2.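

Putting an aromatic ring on this carbon is not enough by itself to change the read-out in this assay: 4-chlorophenyl in place of bromo gives a number 2.4 percentage points higher from compound 1 to compound 3 (within the scatter). What counts here is the group carried on that ring, since chloro in place of methoxy gives a number 63.3 percentage points lower from compound 2 to compound 3 (beyond the scatter). Nothing measured here explains this gap. Still open, on these data alone, is how a hydroxyl or an amine in place of the methoxy would read. Also open, as far as these compounds go, is whether a longer ether, such as ethoxy, would keep the high number seen with methoxy.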